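Swapping a sulfur-bearing chain for a branched alkyl group

The compounds below may be only part of what the source reports. "The series", "measured", "known", "first", "only" and "open" are said of these compounds alone.

Of the compounds shown here, three sharing one core have been tested in a functional assay on the whole organism (Tail, strain ICR) with Mus musculus as the target, in the tail flick test, with a stated time of 120 min, at a dose of 25 umol/kg by the oral route; on this read-out lower numbers stand for a weaker effect and higher numbers for a stronger effect at the one dose given. Compound 1 `CC[C@H](C)[C@H](NC(=O)CN(c1ncnc2c1ncn2C1CCCCO1)C1CC1)C(=O)OCc1ccccc1` gives 20.4%; compound 2 `O=C(CN(c1ncnc2c1ncn2C1CCCCO1)C1CC1)N[C@@H](CC(=O)OCc1ccccc1)C(=O)OCc1ccccc1` gives 7.82%; compound 3 `CSCC[C@H](NC(=O)CN(c1ncnc2c1ncn2C1CCCCO1)C1CC1)C(=O)OCc1ccccc1` gives 28.7%. For the measured compounds named here, no measured compound reads above compound 3: the change is a number 20.9 percentage points higher from compound 2 to compound 3 (beyond the scatter), while the change is only a number 8.3 percentage points higher from compound 1 to compound 3 (within the scatter). Compound 4 `CC(C)[C@H](NC(=O)CN(c1ncnc2c1ncn2C1CCCCO1)C1CC1)C(=O)OCc1ccccc1` is not yet measured. It differs from compound 3 by isopropyl in place of 2-(methylsulfanyl)ethyl on a saturated chain carbon bound to an amide-type nitrogen and a carbonyl carbon. The nearest guide is compound 1, whose sec-butyl group resembles isopropyl, and its step to compound 3 stayed within the scatter. Compound 4 is therefore expected to land close to compound 1, a move of a number 8.7 percentage points lower from compound 3 to compound 4 (within the scatter) in this assay, at an estimated 20% with a range from 8% to 33%.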

Compound 4, a percentage reported as activity, at one dose (the size of the read-out at that dose, not a potency): 25.8%
The estimate for compound 4 lay 5.8 percentage points below the measured number, and the stated range covers the measured number.
By their numbers in this assay, from the lowest: compound 2; then compounds 1, 4 and 3 (each within the scatter of the next).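

In this assay, the isopropyl group gives no reading apart from the sulfur-bearing chain, with a number 2.9 percentage points lower from compound 3 to compound 4 (within the scatter), or from sec-butyl, with a number 5.4 percentage points higher from compound 1 to compound 4 (within the scatter). Sulfur is therefore not needed at this carbon for a reading in this range. The (benzyloxycarbonyl)methyl group of compound 2 does stand apart, with a number 18 percentage points higher from compound 2 to compound 4 (beyond the scatter), though nothing available explains that gap. Open, on these data alone, is whether a chain ending in a carboxylic acid or an amine on this carbon would read like compound 2 or like the other three.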